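Cyanobenzyl for fluorobenzyl on the aromatic nitrogen oxygen

A few compounds are considered here, and "the series" means these few. Any claim that something is new, unique, unknown or untested is made for them only; others in the source may bear on it.

Measured so far:
- compound 1, `CCOC(=O)c1c(C)nc(-c2ccc(OCC(C)C)c(C#N)c2)n1O`: in a functional assay on a cell-free system (plasma, Oryctolagus cuniculus) for inhibition, with stated times of 5 min, 1 min and 6 min (a higher number here means a weaker inhibitor, a lower number a stronger inhibitor), compound 1 gives 16800 nM.
- compound 2, `CCOC(=O)c1[nH]c(-c2cccc(C#N)c2)nc1C`: in this assay compound 2 gives only a limit, > 30000 nM.
- compound 3, `CCOC(=O)c1c(C)nc(-c2cccc(C#N)c2)n1OCc1ccccc1F`: in this assay compound 3 gives 8990 nM.

Compound 3 holds the lowest of the two numbers; compound 1 sits within the scatter of it, so no order between the two is claimed. For the measured compounds named here, compound 2 stands apart only as a limit (the limit of > 30000 nM in this assay, at which 1 of the 3 values shown sits), and the one step that can be measured, an at least 3.3-fold lower number from compound 2 to compound 3 (0.52 log units; beyond the scatter), is at least modest.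

The next compound, compound 4, `CCOC(=O)c1c(C)nc(-c2cccc(C#N)c2)n1OCc1cccc(C#N)c1`, differs from compound 3 as follows: 3-cyanophenyl in place of 2-fluorophenyl on a saturated chain carbon bound to an oxygen on an aromatic ring. Going by the values given here, this change lies on the benzyl carried by the oxygen on the aromatic nitrogen, whereas the single measured step exchanges hydrogen on that nitrogen for the whole (2-fluorobenzyl)oxy group; no measured pair exchanges one aryl for another on that benzyl. Among the compounds with values here, the step from compound 3 to compound 4 therefore has no direct precedent, and the expectation in this assay is a step no larger than the scatter, in no fixed direction, a 1.0-fold higher number from compound 3 to compound 4 (0.00 log units; within the scatter).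

Compound 4 is thus expected near 9000 nM, with the estimate spanning 3000 nM to 27000 nM.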

Compound 4, half-maximal inhibitory concentration: > 30000 nM
Compound 4: only a limit was reported; the forecaster's own chance of this, stated with the estimate: 10%; middle value at least 3.3-fold (0.52 log units) away from the limit.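

In this assay, for the compounds shown here, the exchange on a saturated chain carbon bound to an oxygen on an aromatic ring gives an at least 3.3-fold higher number from compound 3 to compound 4 (0.52 log units; beyond the scatter), the first measured exchange of one aryl for another on this benzyl. The earlier step, an at least 3.3-fold lower number from compound 2 to compound 3 (0.52 log units; beyond the scatter), involved the whole (2-fluorobenzyl)oxy group, whereas the new result shows that a benzyl carried by the oxygen on the aromatic nitrogen does not by itself secure the lower number, since the outcome also depends on the aryl it carries. Compound 4 gives only a limit, and it shares that limit with compound 2: the limit of > 30000 nM in this assay, at which 2 of the 4 values shown sit.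

The true size of the loss stays unknown, and the compounds shown cannot separate the departure of the fluorine from the arrival of the nitrile or from the different placing of the two groups on the phenyl. Plain benzyl, 3-fluorobenzyl and 2-cyanobenzyl on the same oxygen would pull these factors apart, and only a compound giving a number rather than a limit would fix the size of any such step.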